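A few compounds are considered here, and "the series" means these few. Any claim that something is new, unique, unknown or untested is made for them only; others in the source may bear on it.

Of the compounds shown here, three have been measured in an assay on isolated protein for binding affinity to sphingosine 1-phosphate receptor 2 (Homo sapiens), read by surface plasmon resonance; on this read-out higher numbers stand for weaker binding and lower numbers for tighter binding. Compound 1 `CCN(CC)c1cc(NC(=O)NNc2cc(-c3ccc(F)cc3)c3cnn(C)c3n2)cc(Cl)n1` gives 3150 nM. Going by the values given here, compound 2 `Cn1ncc2c(-c3ccc(F)cc3)cc(NNC(=O)Nc3cc(Cl)nc(OCCF)c3)nc21` gives 2790 nM, and the only single-site step measured so far, a 1.1-fold lower number from compound 1 to compound 2 (0.05 log units; within the scatter), lies within the scatter. Compound 3 `CCCCOc1cc(NC(=O)NNc2cc(-c3ccc(OC)cc3)c3cnn(C)c3n2)cc(Cl)n1` gives 4150 nM, the highest of the three numbers, though its distances to compound 1 and to compound 2 are both within the scatter, so no order among the three can be read.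

Compound 4 `CCCCOc1cc(NC(=O)NNc2cc(-c3ccc(F)cc3)c3cnn(C)c3n2)cc(Cl)n1` is not yet measured. It differs from compound 3 in one place: fluoro in place of methoxy on an aromatic carbon. Among the compounds with values here, no measured step changes this position; the one measured step, from compound 1 to compound 2, concerns a different place and was within the scatter. Compound 1 and compound 2 carry the 4-fluorophenyl group that enters here, but each also differs from compound 3 at a second place, so their numbers cannot be assigned to this change alone; what they show is that all three measured numbers in this assay lie within the scatter of one another. The expectation for compound 4 is therefore a step of about a 1.2-fold lower number from compound 3 to compound 4 (0.07 log units; within the scatter), that is, none beyond the scatter in either direction. Compound 4 is estimated at 3500 nM, with a range from 1700 nM to 7500 nM.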

Compound 4, dissociation constant: 2650 nM
The estimate for compound 4 lay 1.3-fold (0.12 log units) above the measured number; measured number inside the range.
By their numbers in this assay, from the lowest: compounds 4, 2, 1 and 3 (each within the scatter of the next).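

Notes on the 4-methoxyphenyl to 4-fluorophenyl change: in this assay this position now has its first single-site reading (a 1.6-fold lower number from compound 3 to compound 4 (0.19 log units; within the scatter)), and on the aromatic carbon para to a large group, fluoro in place of methoxy gives no step beyond the scatter. Compound 4 also links this position to the other site through two further steps, ethyl in place of fluoro on the chain (a 1.1-fold lower number from compound 2 to compound 4 (0.02 log units; within the scatter)) and butoxy in place of diethylamino (a 1.2-fold lower number from compound 1 to compound 4 (0.08 log units; within the scatter)), and neither step goes beyond the scatter, so no group in either place separates from the others among the four compounds. No measurement at hand speaks to why these groups read alike.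

As far as these compounds go, whether another group on this aromatic carbon, such as an amine or a carboxylic acid, would give a step beyond the scatter remains open, as does a longer chain in place of butoxy. From the compounds shown here alone, the fluoro for methoxy step is also seen only once, with butoxy at the other site, so its size with diethylamino or 2-fluoroethoxy there remains unknown.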